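The source may hold more compounds than are shown below. What is called first, only, known or untested is meant among the compounds shown, and "the series" means these compounds.

Measured compounds:
Compound 1 `CCOC(=O)[C@@H](NC(=O)[C@H]1C[C@H](O)CN1C(=O)CCCC(=O)O)[C@@H](C)O[C@@H]1O[C@@H](C)[C@@H](O)C(O)C1O` — in an assay on isolated protein for inhibition of E-selectin (Homo sapiens) (a lower number here means a stronger inhibitor, a higher number a weaker inhibitor), compound 1 gives 100000 nM.
Compound 2 `CCOC(=O)[C@@H](NC(=O)[C@@H]1C[C@H](O)CN1C(=O)CCCC(=O)O)[C@@H](C)O[C@@H]1O[C@@H](C)[C@@H](O)C(O)C1O` — in this assay compound 2 gives 1000000 nM.

Compound 2 holds the highest of the two numbers; its nearest neighbour is compound 1, reached by a 10-fold higher number from compound 1 to compound 2 (1.00 log units; beyond the scatter), a step at the stereocentre on the ring carbon bearing the amide, which rests on (the fact that one of compounds 1 and 2 is drawn with a defined configuration and the other without, at the place where they differ). Compound 3 `CCOC(=O)[C@@H](NC(=O)[C@@H]1C[C@@H](O)CN1C(=O)CCCC(=O)O)[C@@H](C)O[C@@H]1O[C@@H](C)[C@@H](O)C(O)C1O` differs from compound 2 by the two compounds have the same atoms and bonds; at least one stereo element is drawn with a configuration in one of them and without one in the other: 1 of 9 stereo elements differ; a stereocentre at a saturated ring carbon is drawn S in compound 2 and R in compound 3, the hydroxyl-bearing ring carbon. Going by the values given here, no measured step touches that centre, so the only guide is the inversion already seen from compound 1 to compound 2, which moved the number by a modest amount. With compound 2 already so weak, a change at the second ring stereocentre is expected to leave the number roughly where it stands, so a 1.7-fold lower number from compound 2 to compound 3 (0.22 log units; within the scatter) is estimated to lie within the scatter. Compound 3 is therefore expected to give about 600000 nM, between 100000 nM and 2000000 nM.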

Compound 3, half-maximal inhibitory concentration: 300000 nM
For compound 3 the middle estimate is 2.0-fold (0.30 log units) above the measured one, within the range that was stated.
By their numbers in this assay, from the lowest: compound 1; then compound 3; then compound 2.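

Going by these compounds alone, the hydroxyl-bearing ring carbon, which no earlier pair touched, proves to matter in its own right: inverting it gives a 3.3-fold lower number from compound 2 to compound 3 (0.52 log units; beyond the scatter). Both ring stereocentres have now each shown a single-centre step beyond the scatter, even among compounds with numbers this high. The step of a 3.0-fold higher number from compound 1 to compound 3 (0.48 log units; beyond the scatter) spans both centres at once, so it cannot be assigned to either one alone, and the reading of the single-centre step rests on how that centre is drawn: the fact that one of compounds 2 and 3 is drawn with a defined configuration and the other without, at the place where they differ

What the compounds leave open is whether inverting the hydroxyl-bearing carbon has a similar effect when the amide-bearing ring carbon keeps the configuration of compound 1. They also leave open whether an amine or a methoxy group in place of the ring hydroxyl would keep this dependence on configuration.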